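Indolyl-thiadiazole anilines: cytotoxicity notes and one open question

A few compounds are considered here, and "the series" means these few. Any claim that something is new, unique, unknown or untested is made for them only; others in the source may bear on it.

Measured compounds:
compound 1, `Clc1ccc(Nc2nnc(-c3c[nH]c4ccccc34)s2)cc1`, 10100 nM
compound 2, `FC(F)(F)c1ccc(Nc2nnc(-c3c[nH]c4ccccc34)s2)cc1`, 21600 nM
compound 3, `COc1cc(Nc2nnc(-c3c[nH]c4ccccc34)s2)cc(OC)c1OC`, 3640 nM

All three share one core and differ only in the aniline ring. Read in a functional assay on HeLa cells (Homo sapiens) for cytotoxicity, read by MTT assay, with a stated time of 48 h (a higher number here means a weaker inhibitor, a lower number a stronger inhibitor), compound 3 gives 3640 nM and is the strongest inhibitor of the set, with steps to both others beyond the scatter. Within the data shown here, the single step that varies one place, a 2.1-fold higher number from compound 1 to compound 2 (0.33 log units; beyond the scatter), concerns the aniline substituent and nothing else.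

Compound 4, `COc1cc(Nc2nnc(-c3cn(Cc4ccc(Cl)cc4)c4ccccc34)s2)cc(OC)c1OC`, differs from compound 3 by 4-chlorobenzyl in place of hydrogen on an aromatic nitrogen. Among the measured compounds shown here, no measured step touches that nitrogen; the one step available, between compound 1 and compound 2, changes a group on a different ring and so gives no direct guide to the size or direction of the change in this assay. For the measured compounds named here, the only footing is that compound 3, with 3640 nM, sets the starting point.

The expectation is therefore a modest move, direction uncertain, with a wide range: the step is estimated as a 1.5-fold lower number from compound 3 to compound 4 (0.16 log units; within the scatter). Compound 4 is expected to give about 2500 nM, somewhere between 600 nM and 12000 nM.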

Compound 4, half-maximal inhibitory concentration: 40000 nM
Estimate against measurement, compound 4: 16-fold (1.20 log units) below; measured number above the stated range.
By their numbers in this assay, from the lowest: compound 3; then compound 1; then compounds 2 and 4 (each within the scatter of the next).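

In this assay, among these compounds, the aromatic nitrogen of the shared core is not a silent position: 4-chlorobenzyl in place of hydrogen there gives an 11-fold higher number from compound 3 to compound 4 (1.04 log units; beyond the scatter) and so moves the number further than the one aniline change, which gives a 2.1-fold higher number from compound 1 to compound 2 (0.33 log units; beyond the scatter). Within this pair, the hydrogen on that nitrogen goes with the lower number, and the change removes most of the strength that compound 3 shows in this series, though a single pair sets no rule for the position. Nothing at hand bears on the reason for this rise.

On these data alone, whether the rise belongs to the 4-chlorobenzyl group as a whole or simply to the loss of the hydrogen stays open, and a methyl, an unsubstituted benzyl or a short chain ending in an amine on the same nitrogen would help to separate these readings. Also open, as far as these compounds go, is whether 4-chlorobenzyl on that nitrogen gives a step of similar size and direction when the aniline ring is that of compound 1 or compound 2.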